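Adding a cyano group to compound 2

This account rests on a few compounds, and the source may have more. Where it says the series, first, only, none or still open, it means among the compounds named here.

- compound 1 `COc1cc(/C=C2\CN(C)C/C(=C\c3ccncc3)C2=O)cc(OC)c1` at 9500 nM
- compound 2 `O=C1/C(=C/c2cccnc2)CN(S(=O)(=O)c2ccccc2)C/C1=C\c1ccccc1F` at 8210 nM

In a functional assay on HepG2 cells (Homo sapiens) for cytotoxicity, read by MTT assay, with a stated time of 24 h (on this read-out higher numbers stand for weaker inhibition and lower numbers for stronger inhibition), compound 2 reads 8210 nM and compound 1 reads 9500 nM so the two sit within the scatter of each other and cannot be ranked.

The next compound, compound 3 `N#Cc1ccc(S(=O)(=O)N2C/C(=C\c3cccnc3)C(=O)/C(=C/c3ccccc3F)C2)cc1` keeps the whole of compound 2 except for one change. That change is cyano in place of hydrogen on an aromatic carbon and amounts to cyano in place of hydrogen on an aromatic carbon, para to a large group, so that phenylsulfonyl becomes (4-cyanophenyl)sulfonyl.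

Going by the values given here, no two measured compounds here differ in one place alone, so the data hold no direct precedent for this change. In this assay a slight move towards stronger inhibition is expected, though nothing beyond the scatter. The estimated size is a 1.3-fold lower number from compound 2 to compound 3 (0.10 log units; within the scatter) and no more. Compound 3 is expected at 6500 nM within a range from 2500 nM to 15000 nM when it is measured.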

Compound 3, half-maximal inhibitory concentration: 6600 nM
Compound 3: middle estimate off by 1.0-fold (0.01 log units), on the low side; the range from low to high includes it.
By their numbers in this assay, from the lowest: compounds 3, 2 and 1 (each within the scatter of the next).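

In this assay, going by these compounds alone, the step of a 1.2-fold lower number from compound 2 to compound 3 (0.09 log units; within the scatter) is the first comparison here between compounds that differ in one place: cyano in place of hydrogen on an aromatic carbon, para to a large group. On this read-out phenylsulfonyl and (4-cyanophenyl)sulfonyl therefore cannot be told apart, and this position carries the added cyano with the number staying within the scatter of compound 2. Nothing available explains the size of this step.

Going by these compounds, what an amine or a carboxylic acid at this same position would read in this assay remains open. Also open, on these data alone, is whether cyano here would give a step of similar size with other groups elsewhere on the shared core.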